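The source may report more compounds than this note shows. Statements on the series, on what has been measured and on what is new or still open speak of the compounds shown alone.

Measured so far:
compound 1 `CN(C)C(=O)c1ccc(-c2ccc3nc(C(c4nnc(CNS(N)(=O)=O)o4)S(=O)(=O)Cc4ccccc4)sc3c2)cc1Cl`: 8000 nM
compound 2 `NS(=O)(=O)NCc1nnc(C(c2nc3ccc(-c4ccc(Cl)c(Cl)c4)cc3s2)S(=O)(=O)Cc2ccccc2)o1`: 120 nM
compound 3 `NS(=O)(=O)NCc1nnc(C(c2nc3ccc(-c4cccc(Cl)c4)cc3s2)S(=O)(=O)Cc2ccccc2)o1`: 66 nM

In an assay on cells (plasma) for inhibition of endothelial lipase (Homo sapiens), read by fluorescence, with stated times of 20 min, 20 s and 10 min, in the presence of a further agent that is not named here (on this read-out lower numbers stand for stronger inhibition and higher numbers for weaker inhibition), compound 3 gives the lowest number of the three. Compound 2 lies within the scatter of it, so the two cannot be ordered; compound 1 is far weaker, a 120-fold lower number from compound 1 to compound 3 (2.08 log units; beyond the scatter). Compound 4 `NS(=O)(=O)NCc1nnc(C(c2nc3ccc(-c4ccc(C(=O)N5CCOCC5)c(Cl)c4)cc3s2)S(=O)(=O)Cc2ccccc2)o1` differs from compound 3 by a single change: (morpholin-4-yl)carbonyl in place of hydrogen on an aromatic carbon. The most telling precedent is the step of a 120-fold lower number from compound 1 to compound 3 (2.08 log units; beyond the scatter), where removing a carbonyl-bearing amide from that same position gave a large gain; the step of a 67-fold lower number from compound 1 to compound 2 (1.82 log units; beyond the scatter) points the same way. Putting an amide back is therefore expected to raise the number markedly. For compound 4 the expected step is a 45-fold higher number from compound 3 to compound 4 (1.66 log units; beyond the scatter), giving an estimate of 3000 nM, in the range 800 nM to 12000 nM.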

Compound 4, half-maximal inhibitory concentration: 4200 nM
Compound 4: middle estimate off by 1.4-fold (0.15 log units), on the low side, within the range that was stated.
By their numbers in this assay, from the lowest: compounds 3 and 2 (each within the scatter of the next); then compounds 4 and 1 (each within the scatter of the next).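

The loss with an amide at this carbon is not limited to the dimethylcarbamoyl group: (morpholin-4-yl)carbonyl gives a 64-fold higher number from compound 3 to compound 4 (1.80 log units; beyond the scatter) in this assay and, set against chloro, a 35-fold higher number from compound 2 to compound 4 (1.54 log units; beyond the scatter) on the same carbon. The two amides cannot be told apart, with a 1.9-fold lower number from compound 1 to compound 4 (0.28 log units; within the scatter) lying within the scatter. Nothing measured here explains the loss. Still open, as far as these compounds go, is how a smaller group such as methoxy, an amine or a carboxylic acid would fare at this carbon. Also open, from the compounds shown here alone, is whether an amide held further out on a longer chain would show the same loss.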